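Acetoxymethyl in place of 4-methylphenyl: an expected step

The source may hold more compounds than are shown below. What is called first, only, known or untested is meant among the compounds shown, and "the series" means these compounds.

Compound 1 `CCS[C@@H]1[C@H](SCC)[C@@H](Cn2cc(-c3ccc(OC)cc3)nn2)O[C@H]1n1ccc(=O)[nH]c1=O`: 24300 nM
Compound 2 `CCS[C@@H]1[C@H](SCC)[C@@H](Cn2cc(-c3ccc(C)cc3)nn2)O[C@H]1n1ccc(=O)[nH]c1=O`: >= 100000 nM

In a functional assay on LAC cells (Homo sapiens) for cytotoxicity, read by MTT assay, with a stated time of 72 h (on this read-out lower numbers stand for an effect already at smaller amounts and higher numbers for an effect only at larger amounts of compound), compound 1 gives 24300 nM. For compound 2 only a limit of the assay is known, >= 100000 nM, so it stands at the top of the numbers seen (the limit of >= 100000 nM in this assay, at which 1 of the 2 values shown sits). Among the measured compounds shown here, the only measured step, an at least 4.1-fold higher number from compound 1 to compound 2 (0.61 log units; beyond the scatter), concerns methyl against methoxy and does not bear on the change studied here. Compound 3 `CCS[C@@H]1[C@H](SCC)[C@@H](Cn2cc(COC(C)=O)nn2)O[C@H]1n1ccc(=O)[nH]c1=O` differs from compound 2 as follows: acetoxymethyl in place of 4-methylphenyl on an aromatic carbon. With nothing measured that speaks to this change, compound 3 is expected to shift by an estimated at least 1.6-fold lower number from compound 2 to compound 3 (0.22 log units; that floor lies within the scatter). The estimate for compound 3 is 60000 nM, expected between 15000 nM and 100000 nM.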

Compound 3, half-maximal effective concentration: >= 100000 nM
Compound 3: a limit, no number; the forecaster's own chance of this, stated with the estimate: 50%; middle value at least 1.6-fold (0.22 log units) away from the limit.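

In this assay compound 3 gives >= 100000 nM, which is a limit and not a number. Acetoxymethyl in place of 4-methoxyphenyl gives an at least 4.1-fold higher number from compound 1 to compound 3 (0.61 log units; beyond the scatter), so at this position a group with no ring, like 4-methylphenyl before it, does not keep the measurable value of the 4-methoxyphenyl compound. The step between the two compounds at the limit cannot be read, because both sit there: the limit of >= 100000 nM in this assay, at which 2 of the 3 values shown sit.

As far as these compounds go, whether acetoxymethyl and 4-methylphenyl differ at all therefore stays open. So does the reading of an amine, a carboxylic acid or a longer chain at this position.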